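A few compounds are considered here, and "the series" means these few. Any claim that something is new, unique, unknown or untested is made for them only; others in the source may bear on it.

Compound 2, with the structure `Cc1ccc2[nH]c(-n3[nH]c(C)c(Cc4ccc(Cl)cc4)c3=O)nc2c1`, gives 750 nM in an assay on isolated protein for inhibition of alpha-ketoglutarate-dependent dioxygenase alkB homolog 3 (Homo sapiens), read by polymerase chain reaction, with a stated time of 1 h; a lower number here means a stronger inhibitor, a higher number a weaker inhibitor. Among the three numbers known, compound 2 sits well apart from compound 1, whose structure is `Cc1ccc2[nH]c(-n3[nH]c(C)c(C)c3=O)nc2c1` and which gives 2600 nM in this assay, while compound 3, with the structure `Cc1ccc2[nH]c(-n3[nH]c(C)c(Cc4ccc(Cl)c(Cl)c4)c3=O)nc2c1`, gives 720 nM, a number that lies within the scatter of the one for compound 2. The steps that exist are a 3.5-fold lower number from compound 1 to compound 2 (0.54 log units; beyond the scatter), a 3.6-fold lower number from compound 1 to compound 3 (0.56 log units; beyond the scatter) and a 1.0-fold lower number from compound 2 to compound 3 (0.02 log units; within the scatter).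

Compound 4 has the structure `Cc1ccc2[nH]c(-n3[nH]c(C)c(Cc4ccc(-c5ccccc5)cc4)c3=O)nc2c1`. The change from compound 2 is phenyl in place of chloro on an aromatic carbon. Among the measured compounds shown here, no measured step here swaps one group for another on the pendant ring; the step from compound 2 to compound 3 is the only one that alters that ring at all, and it stayed within the scatter. The two larger steps from compound 1 concern the arrival of the whole pendant ring, not its substituent, and so bear on compound 4 only in showing that that part of the molecule can matter. On this footing a step within the scatter, or a small one in either direction, is expected, a 1.2-fold lower number from compound 2 to compound 4 (0.06 log units; within the scatter). Compound 4 is estimated to give 650 nM in this assay, with a range from 250 nM to 1700 nM.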

Compound 4, half-maximal inhibitory concentration: 5300 nM
Beside the measured number, compound 4's estimate is 8.2-fold (0.91 log units) below it; the measured number lies above the stated range.
By their numbers in this assay, from the lowest: compounds 3 and 2 (each within the scatter of the next); then compound 1; then compound 4.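

In this assay, the carbon para to a large group on the pendant ring proves sensitive to what it carries: phenyl in place of chloro gives a 7.1-fold higher number from compound 2 to compound 4 (0.85 log units; beyond the scatter), whereas the added chloro on the same ring gave only a 1.0-fold lower number from compound 2 to compound 3 (0.02 log units; within the scatter) and stayed within the scatter. The pendant ring therefore does not lower the number whatever it bears, since compound 4 at 5300 nM stands above even compound 1 at 2600 nM, so the lower number of compound 2 depends on the substituent as well as on the arrival of the ring. No measurement of any property of these groups is available to account for this rise.

The compounds shown leave open whether the number climbs gradually with the heavy atoms that enter at this carbon or whether the phenyl ring itself is what matters, a question that a methyl, a methoxy or a saturated cyclohexyl group there would address. They also leave open how an amine or a carboxylic acid at this carbon would fare, and whether a phenyl on the other substituted carbon of the pendant ring would give the same rise.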